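This account rests on a few compounds, and the source may have more. Where it says the series, first, only, none or still open, it means among the compounds named here.

Series on one shared core, varied at the aryl group on a nitrogen on an aromatic ring. Compound 1 (`O=C(Nc1nc2ccc([N+](=O)[O-])cc2s1)c1cccnc1Nc1ccccc1`) carries a phenyl there, and in an ADME assay on CV-1 cells (Chlorocebus aethiops) for inhibition, read by MTT assay, with a stated time of 48 h (on this read-out higher numbers stand for weaker inhibition and lower numbers for stronger inhibition), compound 1 gives 70000 nM. Compound 2 (`O=C(Nc1nc2ccc([N+](=O)[O-])cc2s1)c1cccnc1Nc1cc(F)c(F)c(F)c1`) carries 3,4,5-trifluorophenyl in its place. In this assay compound 2 reaches only a limit, > 100000 nM, and no number. So compound 2 stands on a bound rather than a value, the bound described under (the limit of > 100000 nM in this assay, at which 1 of the 2 values shown sits). Going by the values given here, the one measured step reads an at least 1.4-fold higher number from compound 1 to compound 2 (0.15 log units; that floor lies within the scatter), a floor that does not clear the scatter.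

Compound 3 (`O=C(Nc1nc2ccc([N+](=O)[O-])cc2s1)c1cccnc1Nc1ccc(F)cc1`) is the next change: 4-fluorophenyl in place of 3,4,5-trifluorophenyl on a nitrogen on an aromatic ring. Among the compounds with values here, only the step from compound 1 to compound 2 bears on it, and that step is a floor within the scatter, so in this assay no movement beyond the scatter is expected; the change brings the group back toward the phenyl of compound 1. For compound 3 the expected result in this assay is 90000 nM, with a range from 40000 nM to 200000 nM, which as a step from compound 2 means an estimated at least 1.1-fold lower number from compound 2 to compound 3 (0.04 log units; that floor lies within the scatter).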

Compound 3, half-maximal inhibitory concentration: 15000 nM
Compound 3: the middle estimate sits 6.0-fold (0.78 log units) above what was measured; the measured number lies below the stated range.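

In this assay, going by these compounds alone, this position does respond to the aryl group on the nitrogen: adding one fluorine to the phenyl of compound 1 gives a 4.7-fold lower number from compound 1 to compound 3 (0.67 log units; beyond the scatter), the first step between two measured numbers and one that clears the scatter. Removing two of the three fluorines gives an at least 6.6-fold lower number from compound 2 to compound 3 (0.82 log units; beyond the scatter), so inhibition does not strengthen steadily with the count of fluorines on this ring, and compound 2 goes against any such trend. The size of that second step is only a floor, since compound 2 reaches a limit and not a number: the limit of > 100000 nM in this assay, at which 1 of the 3 values shown sits.

From the compounds shown here alone, it remains open whether the stronger inhibition of compound 3 is specific to fluorine or would also appear with 4-chlorophenyl or 4-methoxyphenyl, and a difluorophenyl group would show how much fluorine the position tolerates before inhibition weakens again. Also open, going by these compounds, is how a saturated group such as cyclohexyl would read on the same nitrogen, and whether the trend seen with these three aryl groups holds for any group beyond them.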